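The source may hold more compounds than are shown below. What is called first, only, known or untested is meant among the compounds shown, and "the series" means these compounds.

Measured compounds:
Compound 1, `CCCOC(=O)Nc1ccc([Se]C#N)cc1`, in a functional assay on HTB-54 cells (Homo sapiens) for cytotoxicity, read by MTT assay, with a stated time of 72 h; a higher number here means a weaker inhibitor of growth, a lower number a stronger inhibitor of growth: 51900 nM
Compound 2, `O=C(Nc1ccc([Se][Se]c2ccc(NC(=O)Oc3ccc(F)cc3)cc2)cc1)Oc1ccc(F)cc1`, in this assay: 51800 nM

Compound 1 stands at the top of these two numbers, yet compound 2 lies so close that the two cannot be told apart within the usual scatter of this assay. Compound 3, `N#C[Se]c1ccc(NC(=O)OCc2ccccc2)cc1`, has not yet been tested. It differs from compound 1 in one place: phenyl in place of ethyl on a saturated chain carbon bound to an oxygen next to a carbonyl group. Among the compounds with values here, no measured pair in this set shows a change of this kind, so its size must be judged from the whole picture. A small step is expected from compound 1 to compound 3, probably not beyond the scatter, because compound 1 gives 51900 nM and compound 2, built quite differently, gives 51800 nM: a 1.2-fold lower number from compound 1 to compound 3 (0.06 log units; within the scatter). Compound 3 is therefore estimated at 45000 nM in this assay, within a range from 18000 nM to 110000 nM.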

Compound 3, concentration for total growth inhibition: 50800 nM
Compound 3: middle estimate off by 1.1-fold (0.05 log units), on the low side, and the stated range covers the measured number.
By their numbers in this assay, from the lowest: compounds 3, 2 and 1 (each within the scatter of the next).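

Replacing ethyl with phenyl on a saturated chain carbon bound to an oxygen next to a carbonyl group gives a 1.0-fold lower number from compound 1 to compound 3 (0.01 log units; within the scatter) in this assay. Within the data shown here, this is the only comparison here between compounds that differ in one place, and it shows that adding one six-membered aromatic ring at this position leaves the number within the scatter, so the larger group neither clearly strengthens nor clearly weakens growth inhibition. No supporting measurement bears on this result.

A single change cannot show whether this position is insensitive in general or whether these two groups merely happen to give similar numbers. Going by these compounds, an amine, a carboxylic acid or a longer chain at this place could still test that, and phenyl rings bearing added groups remain open as well.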